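The source may report more compounds than this note shows. Statements on the series, on what has been measured and on what is new or still open speak of the compounds shown alone.

In a functional assay on SNU-638 cells (Homo sapiens) for cytotoxicity, read by MTT assay (on this read-out lower numbers stand for stronger inhibition and higher numbers for weaker inhibition), compound 1 `O=C(/C=C/c1ccc(N2CCCC2)cc1)c1ccc(O)cc1O` gives 5770 nM, the higher of the two numbers recorded; compound 2 `COc1ccc(/C=C/C(=O)c2ccco2)cc1Br` gives 4290 nM, and the two lie within the scatter of each other. Compound 3 `O=C(/C=C/c1ccc(N2CCCC2)cc1)c1ccc(O)cc1` differs from compound 1 by a hydrogen in place of hydroxy on an aromatic carbon. Among the measured compounds shown here, no measured pair shows such a change here, so the step in this assay from compound 1 to compound 3 is expected to be small and to stay within the scatter, written as a 1.2-fold higher number from compound 1 to compound 3 (0.08 log units; within the scatter). Compound 3 is therefore estimated at 7000 nM, in the range 3000 nM to 16000 nM.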

Compound 3, half-maximal inhibitory concentration: 620 nM
For compound 3 the middle estimate is 11-fold (1.05 log units) above the measured one, outside the stated range (below it).
By their numbers in this assay, from the lowest: compound 3; then compounds 2 and 1 (each within the scatter of the next).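

In this assay, hydrogen in place of hydroxy on an aromatic carbon, ortho to a large group and meta to a hydroxy group, gives a 9.3-fold lower number from compound 1 to compound 3 (0.97 log units; beyond the scatter) and a step beyond the scatter. Among the compounds shown here, this is the first sign that the assay responds to a change at this position, and the hydroxy group there is not required for the cytotoxicity seen with compound 3. No measurement shown here accounts for the step. Going by these compounds, whether an amine or a fluorine atom at this position would read like hydrogen or like hydroxy remains open. So does the effect of replacing the remaining hydroxy group of compound 3.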